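The source may report more compounds than this note shows. Statements on the series, on what has been measured and on what is new or still open speak of the compounds shown alone.

Working notes on a small set built on the shared core of compound 1 `ONc1cccc(CNc2cc(Br)cc3[nH]ncc23)c1`, all run in an assay for inhibition of Tryptophan 2,3-dioxygenase (Homo sapiens), with a stated time of 1 h, tested at 10 uM; on this read-out higher numbers stand for more inhibition at the one concentration tested (going by the name of the read-out) and lower numbers for less inhibition. Compound 1 gives "not active" (no number reported) in this assay, so no single number stands for it. Compound 2 `Nc1cc(CNc2cc(Br)cc3[nH]ncc23)ccc1O` likewise gives "not active" (no number reported) in this assay, again without a number. Compound 3 `Brc1cc(NCc2cccc3sccc23)c2cn[nH]c2c1`, of a different build at the amine side, gives 56% in this assay and is the only one with a figure. Among the measured compounds shown here, no two of the measured compounds differ in one place, so no step between them can be stated; compounds 1 and 2 stand together without a number, compound 3 apart from them.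

Compound 4 `OC1CCCC(Nc2cccc(CNc3cc(Br)cc4[nH]ncc34)c2)C1` differs from compound 1 by 3-hydroxycyclohexyl in place of hydroxy on a nitrogen on an aromatic ring. With compound 1 giving no number, the size and direction of the step in this assay cannot be read from anything measured; the change may as well leave the read-out within the scatter as move it either way. Compound 4 is estimated at 15% in this assay, expected between 0% and 45%, with a real chance that it is again reported without a number.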

Compound 4, a percentage reported as inhibition, at one concentration (the size of the read-out at that concentration, not a potency): 50%
Estimate against measurement, compound 4: 35 percentage points below; the measured number lies above the stated range.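

No new step can be read from compound 1 to compound 4, as compound 1 carries no number. No supporting measurement bears on this result. The compounds shown leave open how much of the figure for compound 4 belongs to the (3-hydroxycyclohexyl)amino group.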